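Methoxyphenyl Isomers on an Alkynyl Adenosine Scaffold

The compounds below may be only part of what the source reports. "The series", "measured", "known", "first", "only" and "open" are said of these compounds alone.

Measured compounds:
compound 1 `CNC(=O)[C@@]12C[C@@H]1[C@@H](n1cnc3c(NC)nc(C#Cc4ccc(F)cc4)nc31)[C@H](O)[C@@H]2O`: 27%
compound 2 `CNC(=O)[C@@]12C[C@@H]1[C@@H](n1cnc3c(NC)nc(C#Cc4ccccc4OC)nc31)[C@H](O)[C@@H]2O`: 12%

In an assay on CHO cells for displacement of a labelled ligand from adenosine receptor A1 (Homo sapiens), read by scintillation counting, with a stated time of 60 min, tested at 10 uM (on this read-out lower numbers stand for less inhibition and higher numbers for more inhibition at the one concentration tested (going by the name of the read-out)), compound 1 gives 27%, while compound 2 gives 12%. Compound 2 therefore stands lowest of the two numbers recorded, with compound 1 the nearer neighbour; the step of a number 15 percentage points lower from compound 1 to compound 2 (beyond the scatter) lies beyond the scatter.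

Compound 3 `CNC(=O)[C@@]12C[C@@H]1[C@@H](n1cnc3c(NC)nc(C#Cc4ccc(OC)cc4)nc31)[C@H](O)[C@@H]2O` has not yet been tested in this assay. It differs from compound 2 as follows: 4-methoxyphenyl in place of 2-methoxyphenyl on a triple-bonded carbon. Within the data shown here, no measured step swaps one methoxyphenyl isomer for another, so only the step of a number 15 percentage points lower from compound 1 to compound 2 (beyond the scatter) speaks to this region, and it concerns a different group. That step shows the region can move the read-out by a modest amount, so a change of similar size is plausible in either direction, with no firm direction from the data. Compound 3 is expected to give about 20%, within 5% to 38%, a step of a number 8 percentage points higher from compound 2 to compound 3 (within the scatter) that is uncertain in sign.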

Compound 3, a percentage reported as inhibition, at one concentration (the size of the read-out at that concentration, not a potency): 10%
Compound 3: middle estimate off by 10 percentage points, on the high side; the measured number falls inside the stated range.
By their numbers in this assay, from the lowest: compounds 3 and 2 (each within the scatter of the next); then compound 1.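

In this assay, 4-methoxyphenyl in place of 2-methoxyphenyl on the triple-bonded carbon gives a number 2 percentage points lower from compound 2 to compound 3 (within the scatter), so these two methoxyphenyl isomers cannot be told apart on this read-out. Methoxy in place of fluoro on an aromatic carbon gives a number 17 percentage points lower from compound 1 to compound 3 (beyond the scatter), which shows that the lower reading seen earlier with the 2-methoxyphenyl group is not confined to that one isomer. Nothing available bears on the reason for these numbers.

The compounds shown leave open whether an unsubstituted phenyl, a hydroxyphenyl or an aminophenyl on the triple-bonded carbon would read with the fluoro compound or with the methoxy pair. They also leave open what a longer chain in place of the methoxy group would do to the inhibition.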